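Swapping bromo for trifluoromethoxy on the anilino ring

The source may report more compounds than this note shows. Statements on the series, on what has been measured and on what is new or still open speak of the compounds shown alone.

Measured compounds:
compound 1, `O=C(C1=C(OC2CCCCC2)C(=O)N(CCCn2ccnc2)C1c1ccc(Br)cc1)c1ccccc1`, 29700 nM
compound 2, `O=C(C1=C(Nc2ccc(Br)cc2)C(=O)N(CCCn2ccnc2)C1c1ccc(Br)cc1)c1ccccc1`, 23800 nM

Both compounds share one core and were tested in a functional assay on SAOS-2 cells (Homo sapiens) for antiproliferative activity, read by MTT assay, with a stated time of 72 h; on this read-out higher numbers stand for weaker inhibition and lower numbers for stronger inhibition. Compound 2 gives 23800 nM, the lowest of the two numbers, while compound 1 gives 29700 nM; the step of a 1.2-fold lower number from compound 1 to compound 2 (0.10 log units; within the scatter) lies within the scatter, so the two cannot be told apart.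

Compound 3, `O=C(C1=C(Nc2ccc(OC(F)(F)F)cc2)C(=O)N(CCCn2ccnc2)C1c1ccc(Br)cc1)c1ccccc1`, has not yet been measured. It differs from compound 2 by trifluoromethoxy in place of bromo on an aromatic carbon. Among the compounds with values here, the only measured step, from compound 1 to compound 2, concerns a different part of the molecule and was itself within the scatter, so it offers little guidance for this change; no measured pair varies the group on the anilino ring. Without such a precedent, the expectation is that compound 3 will fall close to compound 2, with a 1.1-fold higher number from compound 2 to compound 3 (0.02 log units; within the scatter) expected to stay within the scatter. Compound 3 is therefore estimated at 25000 nM, with a range from 10000 nM to 60000 nM.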

Compound 3, half-maximal inhibitory concentration: 17900 nM
Compound 3: middle estimate off by 1.4-fold (0.15 log units), on the high side, and the stated range covers the measured number.
By their numbers in this assay, from the lowest: compounds 3, 2 and 1 (each within the scatter of the next).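

In this assay, within the data shown here, this is the first measured change on the anilino ring itself. Trifluoromethoxy, with 5 heavy atoms, takes the place of bromo, with 1 heavy atom, on the aromatic carbon para to a large group (a 1.3-fold lower number from compound 2 to compound 3 (0.12 log units; within the scatter)), so the larger substituent is accepted here without a difference that can be told from the usual scatter. Replacing cyclohexyloxy with (4-(trifluoromethoxy)phenyl)amino on the double-bonded ring carbon (a 1.7-fold lower number from compound 1 to compound 3 (0.22 log units; within the scatter)) likewise gives a pair that cannot be told apart, and nothing available bears on what lies behind these numbers.

From the compounds shown here alone, it remains open whether a different kind of group on the anilino ring, such as an amine or a carboxylic acid, would shift the number beyond the scatter. The other 4-bromophenyl group, carried on the shared core by all three compounds, stays the same throughout, so the effect of a methoxy or hydroxyl group there is also unknown.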